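The source may hold more compounds than are shown below. What is called first, only, known or untested is meant among the compounds shown, and "the series" means these compounds.

In an ADME assay on MT4 cells (Homo sapiens) for cytotoxicity, read by MTT assay, with a stated time of 4 days (a higher number here means that more compound is tolerated, a lower number that less compound is tolerated), compound 1 `COc1cccc(-c2cc(=O)c3cc(N)ccc3o2)c1` gives 247000 nM and compound 2 `Nc1ccc2oc(-c3cccc(F)c3)cc(=O)c2c1` gives 269000 nM. Only these two compounds have been measured, and compound 2 stands level with compound 1, since their numbers cannot be told apart. Compound 3 `Nc1ccc2oc(-c3cccc(C(F)(F)F)c3)cc(=O)c2c1` keeps the core of compound 2 and changes one group: trifluoromethyl in place of fluoro on an aromatic carbon. That is trifluoromethyl in place of fluoro on an aromatic carbon. Among the compounds with values here, one measured step bears on this change, a swap of fluoro in place of methoxy on an aromatic carbon, which gave a 1.1-fold higher number from compound 1 to compound 2 (0.04 log units; within the scatter). It involves a different pair of groups and is a single example, so it is only a weak guide. Even so, no step beyond the scatter is expected in this assay. The estimated change is a 1.2-fold lower number from compound 2 to compound 3 (0.09 log units; within the scatter). For compound 3 the expected value is 220000 nM, with an estimated range from 100000 nM to 400000 nM.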

Compound 3, half-maximal cytotoxic concentration: 138000 nM
Beside the measured number, compound 3's estimate is 1.6-fold (0.20 log units) above it; the range from low to high includes it.
By their numbers in this assay, from the lowest: compounds 3, 1 and 2 (each within the scatter of the next).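

In this assay, trifluoromethyl in place of fluoro gives a 1.9-fold lower number from compound 2 to compound 3 (0.29 log units; within the scatter), and trifluoromethyl in place of methoxy gives a 1.8-fold lower number from compound 1 to compound 3 (0.25 log units; within the scatter), so neither step can be told from the scatter. A group of four heavy atoms can therefore stand in place of a single fluoro on this aromatic carbon, meta to a large group, without a step beyond the scatter, and methoxy, fluoro and trifluoromethyl cannot be separated here. No measurement at hand accounts for these numbers. Going by these compounds, whether a carboxylic acid, a hydroxyl or a longer chain at this position would give a step beyond the scatter remains open. Also open, on these data alone, is whether changes elsewhere on the shared core would leave the numbers this close together.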